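The source may hold more compounds than are shown below. What is called first, only, known or untested is meant among the compounds shown, and "the series" means these compounds.

Measured so far:
Compound 1 `N#CC1=C(N)OC(c2c[nH]c3ccccc23)=C(C#N)C1c1ccc(Br)cc1` — 947 ug/mL
Compound 2 `COc1ccc(C2C(C#N)=C(N)OC(c3c[nH]c4ccccc34)=C2C#N)cc1OC` — 867 ug/mL

The two measured compounds share one core and differ only in the aromatic group that sits on a saturated ring carbon. In a functional assay (a higher number here means a weaker inhibitor, a lower number a stronger inhibitor), compound 1 gives 947 ug/mL, and in the same assay compound 2 gives 867 ug/mL. Compound 2 has the lower of the two numbers, but the step of a 1.1-fold lower number from compound 1 to compound 2 (0.04 log units; within the scatter) lies within the scatter, so the two values cannot be told apart.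

Compound 3 `CN(C)c1ccc(C2C(C#N)=C(N)OC(c3c[nH]c4ccccc34)=C2C#N)cc1` has not yet been measured. It differs from compound 2 in one place: 4-(dimethylamino)phenyl in place of 3,4-dimethoxyphenyl on a saturated ring carbon. For the measured compounds named here, the only measured step that bears on this change is the earlier swap of one aromatic group for another at the same saturated ring carbon, a 1.1-fold lower number from compound 1 to compound 2 (0.04 log units; within the scatter), which brought no change beyond the scatter. On this single precedent, a further swap of the aromatic group at that position is expected to leave this assay essentially unchanged, so the step of a 1.0-fold lower number from compound 2 to compound 3 (0.01 log units; within the scatter) is expected to stay within the scatter. The estimate for compound 3 in this assay is therefore 850 ug/mL, with a range from 400 ug/mL to 1800 ug/mL.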

Compound 3, half-maximal inhibitory concentration: 900 ug/mL
For compound 3 the middle estimate is 1.1-fold (0.02 log units) below the measured one; the range from low to high includes it.
By their numbers in this assay, from the lowest: compounds 2, 3 and 1 (each within the scatter of the next).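

In this assay, 4-(dimethylamino)phenyl in place of 3,4-dimethoxyphenyl on the saturated ring carbon gives a 1.0-fold higher number from compound 2 to compound 3 (0.02 log units; within the scatter) and stays inside the usual noise of the measurement, while dimethylamino in place of bromo on an aromatic carbon gives a 1.1-fold lower number from compound 1 to compound 3 (0.02 log units; within the scatter) and likewise cannot be distinguished from no difference. For the compounds shown here, the earlier compounds offered only one such comparison at this position, whereas three phenyl groups with different substituents, namely 4-bromophenyl, 3,4-dimethoxyphenyl and 4-(dimethylamino)phenyl, now give values that cannot be told apart, and this now includes a group that carries nitrogen. Nothing available here explains why these groups read alike.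

Going by these compounds, all three compounds carry a substituted phenyl ring at this position, so it remains open whether a group without an aromatic ring, such as methyl or cyclohexyl, or a nitrogen-containing ring such as pyridyl, would read the same. On these data alone, it also remains open whether a phenyl ring bearing a carboxylic acid or a primary amine would move the number beyond the scatter.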